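This account rests on a few compounds, and the source may have more. Where it says the series, first, only, none or still open, it means among the compounds named here.

Measured so far in a functional assay on HepG2 cells (Homo sapiens) for cytotoxicity, read by MTT assay, with a stated time of 72 h; a higher number here means a weaker inhibitor, a lower number a stronger inhibitor:
Compound 1 `CNC(=O)c1cc(Oc2ccc(C3=NNC(c4cc(OC)c(OC)c(OC)c4)C3)cc2)ccn1`: 24300 nM
Compound 2 `CNC(=O)c1cc(Oc2ccc(C3=NNC(c4ccc([N+](=O)[O-])cc4)C3)cc2)ccn1`: > 50000 nM

Compound 2 gives > 50000 nM, which is a limit of the assay and not a number. Its true position on the scale is therefore unknown. Compound 3 `CNC(=O)c1cc(Oc2ccc(C3=NNC(c4ccc(Cl)c(Cl)c4)C3)cc2)ccn1` keeps the shared core and differs from compound 2 in one place: 3,4-dichlorophenyl in place of 4-nitrophenyl on a saturated ring carbon. In short, 3,4-dichlorophenyl stands in place of 4-nitrophenyl on a saturated ring carbon. For the measured compounds named here, no measured step shows what this change does in this assay. Going by the values given here, the only numerical reference is compound 1 at 24300 nM, so a modest move towards stronger inhibition, into the region of that value, is expected. The estimated change is an at least 2.5-fold lower number from compound 2 to compound 3 (0.39 log units; beyond the scatter), and it remains uncertain because the starting point is only a limit. Compound 3 is expected at 20000 nM, with an estimated range from 7000 nM to 50000 nM.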

Compound 3, half-maximal inhibitory concentration: 14400 nM
Compound 3: middle estimate off by 1.4-fold (0.14 log units), on the high side; the measured number falls inside the stated range.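

In this assay, this saturated ring carbon, next to the ring nitrogen, now has a measured step showing that the group it carries can change the read-out. Placing 3,4-dichlorophenyl there in place of 4-nitrophenyl gives an at least 3.4-fold lower number from compound 2 to compound 3 (0.54 log units; beyond the scatter), so this single exchange moves the number beyond the scatter. For compound 2, > 50000 nM is a limit of the assay and not a number, so the step gives only a smallest size, and its true size stays unknown because it starts from that limit: the limit of > 50000 nM in this assay, at which 1 of the 3 values shown sits.

The compounds shown leave open whether the step belongs to the two chlorine atoms or to the loss of the nitro group. They also leave open what a plain phenyl, a 4-chlorophenyl or a 4-aminophenyl group would give on this carbon.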